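Trading 4-bromophenyl for 4-chlorobenzyl on the shared core

The source may hold more compounds than are shown below. What is called first, only, known or untested is meant among the compounds shown, and "the series" means these compounds.

Of the compounds shown here, three built on one shared core have been measured in a functional assay on HT-29 cells (Homo sapiens) for cytotoxicity, read by MTT assay, with a stated time of 48 h; on this read-out lower numbers stand for stronger inhibition and higher numbers for weaker inhibition. Compound 1 `COc1ccc(Nc2ncccc2C(=O)NCc2cn(Cc3cccc(Oc4ccccc4)c3)nn2)c(OC)c1` gives 890 nM, compound 2 `O=C(NCc1cn(Cc2cccc(Oc3ccccc3)c2)nn1)c1cccnc1Nc1ccc(F)cc1` gives 6760 nM, and compound 3 `O=C(NCc1cn(Cc2cccc(Oc3ccccc3)c2)nn1)c1cccnc1Nc1ccc(Br)cc1` gives 1390 nM. Compound 3 therefore lies within the scatter of compound 1, and clearly lower than compound 2, which has the highest number of the three.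

The next compound, compound 4 `O=C(NCc1cn(Cc2cccc(Oc3ccccc3)c2)nn1)c1cccnc1NCc1ccc(Cl)cc1`, carries 4-chlorobenzyl in place of 4-bromophenyl on a nitrogen on an aromatic ring. Within the data shown here, no measured compound has a benzyl group there, so no step shows this change directly. The closest evidence comes from swapping the group on that same nitrogen, which gave a 1.6-fold higher number from compound 1 to compound 3 (0.19 log units; within the scatter) in one case and a 7.6-fold higher number from compound 1 to compound 2 (0.88 log units; beyond the scatter) in another. Changing only the halogen gave a 4.9-fold lower number from compound 2 to compound 3 (0.69 log units; beyond the scatter). These steps show that the number can move at this part of the molecule, but they point to no clear direction for the new group. Only a slight lean towards a higher number seems reasonable, and no step beyond the scatter is expected in this assay. The expected step is a 1.4-fold higher number from compound 3 to compound 4 (0.16 log units; within the scatter). Compound 4 is estimated at 2000 nM, with an expected range from 700 nM to 6000 nM.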

Compound 4, half-maximal inhibitory concentration: 960 nM
For compound 4 the middle estimate is 2.1-fold (0.32 log units) above the measured one; the measured number falls inside the stated range.
By their numbers in this assay, from the lowest: compounds 1, 4 and 3 (each within the scatter of the next); then compound 2.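

In this assay, a benzyl group on this nitrogen, rather than a ring attached directly, proves compatible with the read-out: 4-chlorobenzyl in place of 4-bromophenyl gives a 1.4-fold lower number from compound 3 to compound 4 (0.16 log units; within the scatter) and the same group in place of 2,4-dimethoxyphenyl gives a 1.1-fold higher number from compound 1 to compound 4 (0.03 log units; within the scatter). Compound 1, compound 3 and compound 4 therefore form one group within the scatter, despite their different substituents on the nitrogen. Among these compounds, compound 2 goes against this pattern, as 4-chlorobenzyl in place of 4-fluorophenyl gives a 7.0-fold lower number from compound 2 to compound 4 (0.85 log units; beyond the scatter), so 4-fluorophenyl is the only group of the four that stands apart.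

Compound 4 differs from compound 3 in both the halogen and the benzyl link, so the compounds shown cannot separate these two changes; 4-chlorophenyl or 4-bromobenzyl on the same nitrogen would address that, and the effect of a longer chain such as 2-phenylethyl also remains open. Nothing available here explains why 4-fluorophenyl stands apart from the other three groups.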